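A few compounds are considered here, and "the series" means these few. Any claim that something is new, unique, unknown or untested is made for them only; others in the source may bear on it.

Compound 2 `CC1(Cc2ccccc2)OS(=O)(=O)C=C1OCc1ccccc1` is one of the better-tolerated compounds here: in an ADME assay on HEL cells (Homo sapiens) for cytotoxicity, with a stated time of 3 days (a higher number here means that more compound is tolerated, a lower number that less compound is tolerated), compound 2 gives > 400000 nM, which is a limit of the assay rather than a number. Compound 1 `O=S1(=O)C=C(OCc2ccccc2)C(Cc2ccccc2)(Cc2ccccc2)O1` gives 200000 nM. Compound 3 `CCC1(Cc2ccccc2)OS(=O)(=O)C=C1OCC#N` gives > 400000 nM, again a limit. For the measured compounds named here, the only measured step, an at least 2.0-fold higher number from compound 1 to compound 2 (0.30 log units; that floor lies within the scatter), touches a different place from the change studied here, and its size stays within the scatter, in keeping with the limit of > 400000 nM in this assay, at which 2 of the 3 values shown sit.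

Compound 4 `CC(C)C1(Cc2ccccc2)OS(=O)(=O)C=C1OCc1ccccc1` differs from compound 2 by isopropyl in place of methyl on a saturated ring carbon. Going by the values given here, no measured step bears directly on this change, so no shift beyond the scatter is expected in this assay, in either direction.

Compound 4 is therefore expected to give about 400000 nM, between 200000 nM and 800000 nM, a step of a number no higher from compound 2 to compound 4 (the limit leaves the size open).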

Compound 4, minimum cytotoxic concentration: >= 80000 nM
Compound 4: only a limit was reported; the forecaster's own chance of this, stated with the estimate: 70%; the middle value is on the limit's open side.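

Compound 4 is reported only as a limit of the assay, as is compound 2, so neither of its steps, from compound 1 or from compound 2, can be read. The compounds shown leave open whether isopropyl in place of methyl on a saturated ring carbon changes tolerance in this assay.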